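The source may report more compounds than this note shows. Statements on the series, on what has been measured and on what is new or still open speak of the compounds shown alone.

Measured compounds:
Compound 1 `COc1cc(-c2ccnc3cc(-c4c[nH]c5ccccc45)nn23)cc(OC)c1OC` gives 195 nM in a functional assay on HeLa cells (Homo sapiens) for inhibition, read by CCK-8 assay, with a stated time of 48 h; on this read-out higher numbers stand for weaker inhibition and lower numbers for stronger inhibition.
Compound 2 `COc1cc(-c2ccnc3cc(-c4ccc(-c5cnn(C)c5)cc4)nn23)cc(OC)c1OC` gives 1830 nM in this assay.
Compound 3 `COc1cc(-c2ccnc3cc(-c4ccc(C)c(C)c4)nn23)cc(OC)c1OC` gives 241 nM in this assay.

Compound 3 stands second highest of these three numbers. Its nearest neighbour is compound 1, within the scatter; the furthest is compound 2, beyond it. For the measured compounds named here, the only step between two compounds differing in one place, a 1.2-fold higher number from compound 1 to compound 3 (0.09 log units; within the scatter), lies within the scatter.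

Compound 4 `COc1cc(-c2ccnc3cc(-c4ccc(C(F)(F)F)cc4)nn23)cc(OC)c1OC` has not yet been measured in this assay. Compared with compound 3: 4-(trifluoromethyl)phenyl in place of 3,4-dimethylphenyl on an aromatic carbon

Going by the values given here, the one measured step that bears on this change is a 1.2-fold higher number from compound 1 to compound 3 (0.09 log units; within the scatter), which shows that exchanging one aryl group for another on this aromatic carbon left the number essentially unchanged. Compound 2, carrying a different aryl group at the same place, stands well above compounds 1 and 3. Among the compounds with values here, no measured compound carries the 4-(trifluoromethyl)phenyl group, so the guidance is loose. Compound 4 is therefore expected to give a number near that of compound 3, with a 1.7-fold higher number from compound 3 to compound 4 (0.22 log units; within the scatter) expected, a modest rise if any. Compound 4 is estimated at 400 nM, within 150 nM to 1200 nM.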

Compound 4, half-maximal inhibitory concentration: 1840 nM
The estimate for compound 4 lay 4.6-fold (0.66 log units) below the measured number; measured number above the stated range.
By their numbers in this assay, from the lowest: compounds 1 and 3 (each within the scatter of the next); then compounds 2 and 4 (each within the scatter of the next).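

In this assay, the aryl group on this aromatic carbon proves not to be freely exchangeable: there is a 7.6-fold higher number from compound 3 to compound 4 (0.88 log units; beyond the scatter) and a 9.4-fold higher number from compound 1 to compound 4 (0.97 log units; beyond the scatter), both beyond the scatter, whereas the earlier exchange of 1H-indol-3-yl for 3,4-dimethylphenyl stayed within it. Trifluoromethyl in place of 1-methyl-1H-pyrazol-4-yl gives a 1.0-fold higher number from compound 2 to compound 4 (0.00 log units; within the scatter), within the scatter, so this assay does not tell those two groups apart on the phenyl ring. No measurement is at hand that would account for these differences.

The compounds shown leave open whether a phenyl ring carrying a single methyl group would read with 3,4-dimethylphenyl or with 4-(trifluoromethyl)phenyl. They also leave open how an amine or a carboxylic acid on that phenyl ring would read in this series.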